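The compounds below may be only part of what the source reports. "The series", "measured", "known", "first", "only" and "open" are said of these compounds alone.

Compound 1, `CC1=C(C(=O)Nc2ccc(F)cc2)C(c2ccc([N+](=O)[O-])cc2)N=C(SCc2ccccc2Cl)N1`: 6.2%
Compound 2, `CC1=C(C(=O)Nc2ccc([N+](=O)[O-])cc2)C(c2ccc(Br)cc2)N=C(SCc2ccccc2)N1`: 8.2%
Compound 3, `CC1=C(C(=O)Nc2ccc([N+](=O)[O-])cc2)C(c2cccc([N+](=O)[O-])c2)N=C(SCc2ccccc2)N1`: 7.7%

All three numbers come from a functional assay on the whole organism (artery, strain albino) with Rattus norvegicus as the target, with a stated time of 60 min, at a dose of 10 mg/kg by the oral route (a lower number here means less inhibition, a higher number more inhibition at the dose given (going by the name of the read-out)), and lie within the scatter of one another, so none of the three can be set apart. Among the compounds with values here, the only single-point step is a number 0.5 percentage points lower from compound 2 to compound 3 (within the scatter), a change on the saturated ring carbon that leaves the inhibition flat.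

Compound 4, `CC1=C(C(=O)Nc2ccc([N+](=O)[O-])cc2)C(c2cccc([N+](=O)[O-])c2)N=C(SCc2cccc(Cl)c2)N1`, differs from compound 3 by chloro in place of hydrogen on an aromatic carbon. Within the data shown here, no measured step touches this ring. Compound 1, which also carries a chloro on the benzyl ring, gives 6.2% in this assay, a low number like the others. An uneventful step, a number 0.2 percentage points lower from compound 3 to compound 4 (within the scatter), is therefore expected. For compound 4 the estimate is 7.5%, ranging from 0% to 16%.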

Compound 4, a percentage reported as inhibition, in the whole organism at one dose (the size of the read-out at that dose, not a potency): 8.2%
Compound 4: middle estimate off by 0.7 percentage points, on the low side; the measured number falls inside the stated range.
By their numbers in this assay, from the lowest: compounds 1, 3, 2 and 4 (each within the scatter of the next).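

In this assay the change from benzyl to 3-chlorobenzyl gives a number 0.5 percentage points higher from compound 3 to compound 4 (within the scatter) and sets neither compound apart. Within the data shown here, this is the first reading of this ring in a single-point step, since compound 1 also carries a chloro but differs from the others in more than one place. No measured evidence bears on the result.

Going by these compounds, whether any group on this ring can move the inhibition beyond the scatter stays open. An amine or a carboxylic acid in place of the chloro would test that, as all four numbers remain low.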